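The compounds below may be only part of what the source reports. "The series", "measured", "known", "first", "only" and "open" are said of these compounds alone.

Working notes on the series. In a functional assay on SW480 cells (Homo sapiens) for cytotoxicity, read by sulforhodamine B assay, with a stated time of 48 h (on this read-out lower numbers stand for stronger inhibition and higher numbers for weaker inhibition), compound 1 (`COc1ccc(/C=C/C(=O)c2cccc(Br)c2)cc1OC`) gives "not determined" (no result reported), so it has no single number to stand on. Compound 3 (`COc1ccc(/C=C/C(=O)c2cccc(Br)c2)cc1`) is in the same position, at "not determined" (no result reported). Within the data shown here, the only number so far belongs to compound 2 (`O=C(/C=C/c1cccc(Br)c1)c1cccc(-c2cccc(F)c2)c1`), which reads 8610 nM, and no step between measured compounds is available.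

Compound 4 (`COc1ccc(/C=C/C(=O)c2cccc(-c3cccc(F)c3)c2)cc1OC`) has not yet been measured. The change under study is 3-fluorophenyl in place of bromo on an aromatic carbon, with 3-fluorophenyl in place of bromo on an aromatic carbon, meta to a large group.

With no value for compound 1, this step cannot be sized from data. The working expectation in this assay is no shift beyond the scatter, with neither direction favoured. Among the measured compounds shown here, the only anchor is compound 2, which also carries a 3-fluorophenyl group and reads 8610 nM, so the range has to stay wide. For compound 4 the expected value is 8000 nM, with an estimated range of 2500 nM to 25000 nM.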

Compound 4, half-maximal inhibitory concentration: 2970 nM
Estimate against measurement, compound 4: 2.7-fold (0.43 log units) above; the measured number falls inside the stated range.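

In this assay, among these compounds, compound 1 gives "not determined" (no result reported) and compound 4 gives 2970 nM, so no step between them can be read. The compounds shown leave open what replacing bromo with 3-fluorophenyl does to the read-out on this core. No supporting evidence bears on this result.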